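The compounds below may be only part of what the source reports. "The series", "measured", "known", "first", "only" and "open" are said of these compounds alone.

In a functional assay on SF-268 cells (Homo sapiens) for inhibition (on this read-out lower numbers stand for stronger inhibition of growth and higher numbers for weaker inhibition of growth), compound 2 `NS(=O)(=O)c1ccc(/C=C/c2ccc(F)cc2)cc1` gives 20500 nM, and compound 1 `COc1cc(/C=C/c2ccc(S(N)(=O)=O)cc2)cc(OC)c1` gives 28300 nM, so these two values lie within the scatter of each other. Set against compound 2, compound 3 `NS(=O)(=O)c1ccc(/C=C/c2cccc(O)c2)cc1` gives 65600 nM, and this higher number lies beyond the scatter. Compound 4 `CN(C)c1ccc(/C=C/c2ccc(S(N)(=O)=O)cc2)cc1` has not yet been measured. Its structure departs from compound 2 by dimethylamino in place of fluoro on an aromatic carbon, with dimethylamino in place of fluoro on an aromatic carbon. Among the compounds with values here, no measured pair of compounds shows this kind of change, so no step beyond the scatter is expected in this assay. The expected step is a 1.4-fold lower number from compound 2 to compound 4 (0.14 log units; within the scatter). For compound 4 the estimated value is 15000 nM, with an expected range from 4000 nM to 50000 nM.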

Compound 4, concentration for 50% growth inhibition: 7160 nM
Compound 4: middle estimate off by 2.1-fold (0.32 log units), on the high side; measured number inside the range.
By their numbers in this assay, from the lowest: compound 4; then compounds 2 and 1 (each within the scatter of the next); then compound 3.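

With this result, the position on an aromatic carbon para to a large group gains its first direct comparison in this assay. Dimethylamino in place of fluoro gives a 2.9-fold lower number from compound 2 to compound 4 (0.46 log units; beyond the scatter), so the position is not indifferent to this change, which the earlier compounds, with no pair differing in one place, could not show. Nothing available accounts for this step.

The compounds shown leave open whether a plain amino group or diethylamino at this position would give a similar step. This single pair also cannot tell whether the step would recur on another core.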